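A few compounds are considered here, and "the series" means these few. Any claim that something is new, unique, unknown or untested is made for them only; others in the source may bear on it.

Measured compounds:
Compound 1 `Oc1ccc(-c2cc(-c3ccccn3)nc(-c3ccccc3Cl)c2)cc1`: "not determined" (no result reported) in an ADME assay on HEK293 cells (Homo sapiens) for cytotoxicity, read by CCK-8 assay and cell counting, with a stated time of 2 days; a lower number here means a stronger inhibitor, a higher number a weaker inhibitor.
Compound 2 `Oc1ccc(-c2cc(-c3ccccc3)nc(-c3ccccc3Cl)c2)cc1`: 3930 nM in this assay.

Compound 2 therefore holds the only number shown, and compound 1 offers nothing to compare it with. Compound 3 `Oc1ccc(-c2cc(-c3cccs3)nc(-c3ccccc3Cl)c2)cc1` differs from compound 2 by thiophen-2-yl in place of phenyl on an aromatic carbon. Among the compounds with values here, no measured step of this kind exists here to guide the expectation. One aromatic ring is exchanged for another of similar shape, so the step from compound 2 to compound 3 is expected to stay within the usual scatter, with no clear direction: a 1.0-fold higher number from compound 2 to compound 3 (0.01 log units; within the scatter). Compound 3 is accordingly estimated at 4000 nM, with a range from 1500 nM to 11000 nM.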

Compound 3, half-maximal inhibitory concentration: 5220 nM
For compound 3 the middle estimate is 1.3-fold (0.12 log units) below the measured one; low and high end bracket the measured number.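

Thiophen-2-yl in place of phenyl on this aromatic carbon, next to the ring nitrogen, gives a 1.3-fold higher number from compound 2 to compound 3 (0.12 log units; within the scatter) in this assay. This first readable step at the position shows that a five-membered aromatic ring containing sulfur and a six-membered all-carbon aromatic ring give numbers that cannot be told apart here. Nothing shown bears on the reason for this result. Going by these compounds, whether an amine, a carboxylic acid or a longer alkyl chain on the same carbon would shift the number beyond the scatter remains open.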